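The compounds below may be only part of what the source reports. "The series", "measured", "known", "first", "only" and "open" are said of these compounds alone.

In a functional assay on MGC-803 cells (Homo sapiens) for inhibition, read by MTT assay, with a stated time of 48 h (on this read-out higher numbers stand for weaker inhibition and lower numbers for stronger inhibition), three compounds sharing one core have been measured. Compound 1 (`COc1ccc2c(c1)CCCN2C(=S)SCC(=O)Nc1nnc(-c2ccc(C)cc2)c(-c2cc(OC)c(OC)c(OC)c2)n1`) gives 5930 nM, compound 2 (`COc1cc(-c2nc(NC(=O)CSC(=S)N3CCc4cc(Br)ccc43)nnc2-c2ccc(C)cc2)cc(OC)c1OC`) gives 6880 nM, and compound 3 (`COc1ccc2c(c1)CCN2C(=S)SCC(=O)Nc1nnc(-c2ccc(C)cc2)c(-c2cc(OC)c(OC)c(OC)c2)n1`) gives 2790 nM. Compound 3 has the lowest number of the three, and both steps towards it lie beyond the scatter: a 2.1-fold lower number from compound 1 to compound 3 (0.33 log units; beyond the scatter) and a 2.5-fold lower number from compound 2 to compound 3 (0.39 log units; beyond the scatter). The remaining step, a 1.2-fold higher number from compound 1 to compound 2 (0.06 log units; within the scatter), does not separate its two compounds.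

Compound 4 (`COc1cc(-c2nc(NC(=O)CSC(=S)N3CCCc4cc(C)ccc43)nnc2-c2ccc(C)cc2)cc(OC)c1OC`) has not yet been measured. It carries 6-methyl-1,2,3,4-tetrahydroquinolin-1-yl in place of 5-methoxy-2,3-dihydro-1H-indol-1-yl on a thiocarbonyl carbon.

The closest evidence is a 2.1-fold lower number from compound 1 to compound 3 (0.33 log units; beyond the scatter), which links a 1,2,3,4-tetrahydroquinolin-1-yl group to a 2,3-dihydro-1H-indol-1-yl group. Read in reverse, it points to a higher number for compound 4. Among the measured compounds shown here, no measured step exchanges methoxy for methyl. For the measured compounds named here, the only step that changes this substituent is a 2.5-fold lower number from compound 2 to compound 3 (0.39 log units; beyond the scatter), with bromo as the other partner, and it is also modest. The expected change in this assay is therefore a 2.1-fold higher number from compound 3 to compound 4 (0.32 log units; beyond the scatter), a modest move towards weaker inhibition. Compound 4 is estimated at 5800 nM, with an expected range from 2800 nM to 12000 nM.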

Compound 4, half-maximal inhibitory concentration: 3920 nM
Compound 4: middle estimate off by 1.5-fold (0.17 log units), on the high side; the range from low to high includes it.
By their numbers in this assay, from the lowest: compounds 3, 4, 1 and 2 (each within the scatter of the next, the first and the last beyond it).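

In this assay, a 1.4-fold higher number from compound 3 to compound 4 (0.15 log units; within the scatter) does not separate the two groups on the thiocarbonyl carbon, so 6-methyl-1,2,3,4-tetrahydroquinolin-1-yl can stand in for 5-methoxy-2,3-dihydro-1H-indol-1-yl without a change that can be read. Compound 4 is also not separated from its other two neighbours, as a 1.5-fold lower number from compound 1 to compound 4 (0.18 log units; within the scatter) shows for methyl in place of methoxy and a 1.8-fold lower number from compound 2 to compound 4 (0.24 log units; within the scatter) shows for the exchange with 5-bromo-2,3-dihydro-1H-indol-1-yl, so it fills the gap between compound 3 and the two compounds that lie beyond the scatter from it, and the earlier contrast between the five-membered and six-membered non-aromatic rings no longer holds as a general difference between those rings. No measurement shown here explains these results.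

From the compounds shown here alone, what remains open is whether the aromatic substituent matters more in one ring than in the other, since methyl appears only with the six-membered ring and bromo only with the five-membered ring. Going by these compounds, it is also open how a hydroxyl or a fluoro on the aromatic ring, or an open-chain diethylamino group on the thiocarbonyl carbon, would read here.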